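This account rests on a few compounds, and the source may have more. Where it says the series, first, only, none or still open, it means among the compounds named here.

Working notes on the series. Going by the values given here, compound 2 `CCC(C)(C)Cc1c[nH]c(CCc2ccc(-c3cccc(C#N)n3)cc2)n1` gives 26 nM in a functional assay on HEK293 cells for agonist activity at Bombesin receptor subtype-3 (Mus musculus), read by luminescence and calcium flux, with a stated time of 10 min (a higher number here means that more compound is needed for the effect, a lower number that less compound is needed), and stands at the lower end of the two numbers measured so far. Among the compounds with values here, compound 1 `CCC(C)(C)Cc1c[nH]c(CCc2ccc(-n3ccnn3)cc2)n1` gives 57 nM in this assay; the only measured step, a 2.2-fold lower number from compound 1 to compound 2 (0.34 log units; beyond the scatter), swaps one aryl substituent for another at the same position. Compound 3 `CCC(C)(C)Cc1c[nH]c(CCc2ccc(-c3cnsc3)cc2)n1` differs from compound 2 by 1,2-thiazol-4-yl in place of 6-cyanopyridin-2-yl on an aromatic carbon, again at the position para to a large group on the ring of carbon only. Within the data shown here, only the step from compound 1 to compound 2 bears on this change, and it shows that exchanging one five-membered heteroaryl for a six-membered one moved the number by a modest margin. Compound 3 returns to a five-membered ring with two hetero atoms, so the expected step of a 1.7-fold higher number from compound 2 to compound 3 (0.24 log units; within the scatter) is small, probably back toward compound 1. Compound 3 is estimated at 45 nM, with a range of 15 nM to 140 nM.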

Compound 3, half-maximal effective concentration: 6.9 nM
For compound 3 the middle estimate is 6.5-fold (0.81 log units) above the measured one; measured number below the stated range.
By their numbers in this assay, from the lowest: compound 3; then compound 2; then compound 1.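

At this position on the ring of carbon only, the 1,2-thiazol-4-yl group gives the lowest number of the series in this assay, with a 3.8-fold lower number from compound 2 to compound 3 (0.58 log units; beyond the scatter) and an 8.3-fold lower number from compound 1 to compound 3 (0.92 log units; beyond the scatter). Ring size alone does not order the three compounds: the two five-membered rings stand at opposite ends, with the six-membered 6-cyanopyridin-2-yl between them. Nothing available explains why the 1,2-thiazol-4-yl group differs from the other two.

Open, going by these compounds, is whether the lower number goes with the sulfur or with attachment through a ring carbon rather than a ring nitrogen; a thiophen-3-yl or a pyrazol-4-yl group at this position would separate the two. Also open, on these data alone, are how a plain phenyl or an amine-bearing ring would read, and whether this order holds with a different chain on the shared core.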